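A few compounds are considered here, and "the series" means these few. Any claim that something is new, unique, unknown or untested is made for them only; others in the source may bear on it.

Compounds measured so far:
- Compound 1, `COC(=O)c1ccc(COc2ccc(CNC(=O)[C@@H]3CCC(=O)N3Cc3ccccc3)cc2)cc1`: in an assay on HEK293 cells for inhibition of Ataxin-2 (Mus musculus), read by fluorescence and Amplex Red (a lower number here means a stronger inhibitor, a higher number a weaker inhibitor), compound 1 gives > 5000 nM, which is a limit of the assay and not a number.
- Compound 2, `NS(=O)(=O)c1ccc(COc2ccc(CNC(=O)[C@@H]3CCC(=O)N3Cc3ccc(F)cc3)cc2)cc1`: compound 2 gives > 5000 nM, again a limit rather than a number.
- Compound 3, `CC1(C)OB(c2ccc(COc3ccc(CNC(=O)[C@@H]4CCC(=O)N4Cc4ccc(F)cc4)cc3)cc2)OC1(C)C`: compound 3 gives 120 nM.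

Compound 1 therefore stands at the limit, where (the limit of > 5000 nM in this assay, at which 2 of the 3 values shown sit); nothing more precise is known about it. Compound 4, `O=C(O)c1ccc(COc2ccc(CNC(=O)[C@@H]3CCC(=O)N3Cc3ccccc3)cc2)cc1`, differs from compound 1 in one place: hydrogen in place of methyl on an oxygen next to a carbonyl group, that is, a hydrogen in place of methyl on an oxygen next to a carbonyl group, turning the methoxycarbonyl group into a carboxy group.

Among the compounds with values here, only one measured step exists, an at least 41-fold lower number from compound 2 to compound 3 (1.61 log units; beyond the scatter), and it concerns a different exchange of groups, a boronate ring in place of a sulfonamide, so it gives no direct guide to the ester-to-acid change. With compound 1 known only as a limit, no step beyond the scatter can be predicted in either direction, and the expected change is a step that the limit leaves unreadable from compound 1 to compound 4. Compound 4 is therefore expected to give about 6000 nM, within 1500 nM to 25000 nM, most likely reported again as a limit.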

Compound 4, half-maximal inhibitory concentration: 4500 nM
The estimate for compound 4 lay 1.3-fold (0.12 log units) above the measured number; the measured number falls inside the stated range.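

In this assay compound 4 gives 4500 nM, so the 4-carboxyphenyl group yields an actual measured number. Compound 1 gives > 5000 nM, which is a limit of the assay and not a number. Exchanging methoxycarbonyl for carboxy gives an at least 1.1-fold lower number from compound 1 to compound 4 (0.04 log units; that floor lies within the scatter), and the true size of this step stays unknown because compound 1 sits at that limit: the limit of > 5000 nM in this assay, at which 2 of the 4 values shown sit.

From the compounds shown here alone, whether a primary amide or a hydroxymethyl group in place of the carboxy group would give a lower number than compound 4 remains open. Also open, going by these compounds, is what the carboxy group would give alongside the fluorine on the benzyl group, which compound 2 and compound 3 carry and compound 4 lacks.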